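Pyrrolidine acyl cap: ethylcarbamoyl in place of pivaloyl

The source may hold more compounds than are shown below. What is called first, only, known or untested is meant among the compounds shown, and "the series" means these compounds.

Within the data shown here, compound 2 `CC(C)(C)C(=O)N1CCC[C@H]1C(=O)N1CCC(NS(=O)(=O)c2cc(S(=O)(=O)c3ccccc3)ccc2C(F)(F)F)CC1` stands level with compound 1 `CC(C)C(=O)N1CCC[C@H]1C(=O)N1CCC(NS(=O)(=O)c2cc(S(=O)(=O)c3ccccc3)ccc2C(F)(F)F)CC1`: in an assay on isolated protein for binding affinity to secreted frizzled-related protein 1 (Homo sapiens), read by fluorescence (a lower number here means a stronger inhibitor, a higher number a weaker inhibitor), compound 2 gives 40 nM and compound 1 gives 40 nM, and the single step between them, no change at the digits printed from compound 1 to compound 2 (within the scatter), stays within the scatter. Compound 3 `CCNC(=O)N1CCC[C@H]1C(=O)N1CCC(NS(=O)(=O)c2cc(S(=O)(=O)c3ccccc3)ccc2C(F)(F)F)CC1` differs from compound 2 in one place: ethylamino in place of tert-butyl on a carbonyl carbon, so that (tert-butyl)carbonyl becomes ethylcarbamoyl on the ring nitrogen of the shared core. Among the measured compounds shown here, only one measured step bears on this position, no change at the digits printed from compound 1 to compound 2 (within the scatter), and it shows that enlarging the cap at this carbonyl carbon left the read-out unmoved; the present change swaps carbon for a nitrogen carrying a hydrogen-bond donor, which no measured pair covers. With no step beyond the scatter at this site, compound 3 is expected to sit close to compound 2, with the step of a 1.3-fold higher number from compound 2 to compound 3 (0.10 log units; within the scatter) estimated as no change beyond the scatter. The estimate for compound 3 in this assay is 50 nM, within 15 nM to 160 nM.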

Compound 3, half-maximal inhibitory concentration: 30 nM
Estimate against measurement, compound 3: 1.7-fold (0.22 log units) above, and the stated range covers the measured number.
By their numbers in this assay, from the lowest: compounds 3, 1 and 2 (each within the scatter of the next).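

In this assay, the swap from an all-carbon cap to ethylamino on this carbonyl carbon stays within the scatter against both earlier caps: a 1.3-fold lower number from compound 2 to compound 3 (0.12 log units; within the scatter) and a 1.3-fold lower number from compound 1 to compound 3 (0.12 log units; within the scatter). The earlier step compared only isopropyl with tert-butyl, whereas these steps extend the flat read-out to a cap with a nitrogen carrying a hydrogen-bond donor, so the series now holds at this position across both kinds of cap. Nothing available explains why the read-out stays flat across these three caps.

From the compounds shown here alone, whether the nitrogen's hydrogen matters remains open, and dimethylamino on the same carbonyl carbon would address that. Going by these compounds, how far the flat read-out extends is also open, as a longer chain, a phenyl ring or a carboxylic acid at this position could each read differently.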